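The source may hold more compounds than are shown below. What is called first, only, known or untested is meant among the compounds shown, and "the series" means these compounds.

Compound 1 `CCn1ccc2cc(/C(=N/O)c3ccc(OC)c(OC)c3OC)ccc21`: > 10000 nM
Compound 2 `COc1ccc(/C(=N\N)c2ccc3c(ccn3C)c2)c(OC)c1OC`: > 10000 nM

In a functional assay on A549 cells (Homo sapiens) for cytotoxicity, read by XTT assay, with a stated time of 72 h (a higher number here means a weaker inhibitor, a lower number a stronger inhibitor), compound 1 gives > 10000 nM, which is a limit of the assay and not a number. Compound 2 stands at > 10000 nM in this assay, again a limit and not a number. These two results are the whole of the measured record, summed up as the limit of > 10000 nM in this assay, at which 2 of the 2 values shown sit, so neither compound has an exact value to work from.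

Compound 3 `CCn1ccc2cc(/C(=N/N)c3ccc(OC)c(OC)c3OC)ccc21` has not yet been measured. Compared with compound 2, it carries this change: methyl in place of hydrogen on a saturated chain carbon bound to an aromatic nitrogen. In plain terms, the methyl becomes an ethyl. Among the measured compounds shown here, no measured step between any two compounds is available to size such a change, so the expectation rests on compound 2 and its limit of > 10000 nM. What is expected is a step that the limit leaves unreadable from compound 2 to compound 3, a step no larger than the usual scatter and with no firm direction, and this assay may well report only a limit again. The estimated value for compound 3 is 12000 nM, with an expected range of 4000 nM to 40000 nM.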

Compound 3, half-maximal inhibitory concentration: > 10000 nM
Compound 3 was reported as a limit; the forecaster's own chance of this, stated with the estimate: 85%; the middle value does not contradict the limit.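

In this assay compound 3 gives > 10000 nM, again a limit and not a number. Among the compounds shown here, no step from compound 1 or compound 2 to compound 3 can be read, because all three results stand at the same limit: the limit of > 10000 nM in this assay, at which 3 of the 3 values shown sit. The compounds shown leave open whether methyl to ethyl, or amino in place of hydroxy on a double-bonded nitrogen, changes the result in this assay at all.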